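Sulfonamide nitrogen variation from compound 2 to compound 3

The source may hold more compounds than are shown below. What is called first, only, known or untested is meant among the compounds shown, and "the series" means these compounds.

Compound 1 `CC(C)(C)c1cc(C(C)(C)C)c2oc(=O)c(/C=N/c3ccc(S(=O)(=O)Nc4nccs4)cc3)c(Cl)c2c1` and compound 2 `CC(C)(C)c1cc(C(C)(C)C)c2oc(=O)c(/C=N/c3ccc(S(=O)(=O)NC(=N)N)cc3)c(Cl)c2c1` share one core and differ only in the group on the sulfonamide nitrogen. In a functional assay on MCF7 cells (Homo sapiens) for cytotoxicity, read by CCK-8 assay, with a stated time of 48 h (a lower number here means a stronger inhibitor, a higher number a weaker inhibitor), compound 1 gives 12 nM and compound 2 gives 18 nM. Compound 2 holds the higher of the two numbers, but the step is a 1.5-fold higher number from compound 1 to compound 2 (0.18 log units; within the scatter) and stays within the scatter, so the two cannot be told apart. Compound 3 `Cc1cc(NS(=O)(=O)c2ccc(/N=C/c3c(Cl)c4cc(C(C)(C)C)cc(C(C)(C)C)c4oc3=O)cc2)no1` is not yet measured; it differs from compound 2 by a group of 6 heavy atoms (4 carbon, 1 nitrogen, 1 oxygen; one five-membered aromatic ring with 2 hetero atoms) in place of a group of 3 heavy atoms (1 carbon, 2 nitrogen; no ring), on a sulfonamide nitrogen. Within the data shown here, the one measured step that bears on this exchange also swapped a group at that nitrogen, with a five-membered aromatic ring with 2 hetero atoms on one side of the swap, and gave only a 1.5-fold higher number from compound 1 to compound 2 (0.18 log units; within the scatter). No shift beyond the scatter is therefore expected in this assay for compound 3, in either direction. Compound 3 is estimated at 14 nM, with a range of 6 nM to 35 nM, which means an expected step of a 1.3-fold lower number from compound 2 to compound 3 (0.11 log units; within the scatter).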

Compound 3, half-maximal inhibitory concentration: 64 nM
Compound 3: middle estimate off by 4.6-fold (0.66 log units), on the low side; measured number outside the range, above it.
By their numbers in this assay, from the lowest: compounds 1 and 2 (each within the scatter of the next); then compound 3.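

The sulfonamide nitrogen is not indifferent to its group in this assay: the exchange gives a 3.6-fold higher number from compound 2 to compound 3 (0.55 log units; beyond the scatter), and the exchange between the two ring groups gives a 5.3-fold higher number from compound 1 to compound 3 (0.73 log units; beyond the scatter). Having a five-membered aromatic ring with 2 hetero atoms at this nitrogen therefore does not fix the number, since 1,3-thiazol-2-yl and 5-methyl-1,2-oxazol-3-yl both carry such a ring yet lie apart, while the ringless group of compound 2 stays within the scatter of compound 1. No measurement at hand accounts for this shift.

The compounds shown leave open whether the step follows the methyl group or the ring atoms of 5-methyl-1,2-oxazol-3-yl. An unsubstituted 1,2-oxazol-3-yl on the same nitrogen would separate the two.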